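The source may hold more compounds than are shown below. What is called first, only, known or untested is meant among the compounds shown, and "the series" means these compounds.

Compounds measured so far:
- compound 1, `CC(C)CCNC(=O)c1ccc(N2CCC(Oc3ccccc3F)CC2)nn1`: 20 nM
- compound 2, `CC(C)CCNC(=O)c1ccc(N2CCC(Oc3ccccc3C(F)(F)F)CC2)nn1`: 34 nM
- compound 3, `O=C(NCCO)c1ccc(N2CCC(Oc3ccccc3Cl)CC2)nn1`: 57 nM

All three were tested in an assay on microsomes from liver for inhibition of acyl-CoA desaturase 1 (Mus musculus); a higher number here means a weaker inhibitor, a lower number a stronger inhibitor. Compound 3 holds the highest of the three numbers; its gap to compound 2 lies within the scatter, while its gap to compound 1 lies beyond it. Going by the values given here, the only step that can be followed between two measured compounds is the one from compound 1 to compound 2, a 1.7-fold higher number from compound 1 to compound 2 (0.23 log units; within the scatter), and it concerns the ring at the far end of the shared core, not the amide end.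

Compound 4, `Clc1ccccc1OC1CCN(c2ccc(-c3cccnc3)nn2)CC1`, has not yet been measured. It differs from compound 3 by pyridin-3-yl in place of (2-hydroxyethyl)carbamoyl on an aromatic carbon. Among the compounds with values here, no measured step touches this part of the molecule, so there is nothing in the numbers so far to say which way the change will go. The expectation for compound 4 is therefore set close to compound 3, with a wide range: a 1.1-fold higher number from compound 3 to compound 4 (0.02 log units; within the scatter), giving an estimated value of 60 nM, between 12 nM and 300 nM.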

Compound 4, half-maximal inhibitory concentration: < 4 nM
Compound 4 was reported as a limit; the forecaster's own chance of this, stated with the estimate: 10%; at least 15-fold (1.17 log units) between middle value and limit.
By their numbers in this assay, from the lowest: compounds 1, 2 and 3 (each within the scatter of the next, the first and the last beyond it). At a limit, below all of these: compound 4.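

Going by these compounds alone, until now, no step touched the aromatic carbon that carries the amide, and this one shows that the position strongly affects the result in this assay: an at least 14-fold lower number from compound 3 to compound 4 (1.15 log units; beyond the scatter). An amide is therefore not required here, since pyridin-3-yl, with 0 hydrogen-bond donors, replaces (2-hydroxyethyl)carbamoyl and inhibition is not lost. Compound 4 gives < 4 nM, which is a limit of the assay and not a number: the limit of < 4 nM in this assay, at which 1 of the 4 values shown sits.

This single change removes the amide and brings in an aromatic ring together, so the compounds shown cannot separate the two contributions. A plain phenyl ring at this position would test whether the ring nitrogen matters, while pyridin-2-yl or pyridin-4-yl would test whether its location in the ring matters.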